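This account rests on a few compounds, and the source may have more. Where it says the series, first, only, none or still open, it means among the compounds named here.

Compound 3 `CC(Oc1cccnc1Nc1cnn(C)c1)c1cccc(C(=O)NCc2ccc(F)c(Cl)c2)c1` gives the lowest number of the three measured compounds in a functional assay on HCC78 cells (Homo sapiens) for antiproliferative activity, read by MTT assay, with a stated time of 48 h (on this read-out higher numbers stand for weaker inhibition and lower numbers for stronger inhibition), namely 7800 nM. Compound 1 `CC(Oc1cccnc1Nc1cnn(C)c1)c1cccc(C(=O)NCc2ccc(F)cc2)c1` gives 68500 nM, and compound 2 `COc1cccc(CNC(=O)c2cccc(C(C)Oc3cccnc3Nc3cnn(C)c3)c2)c1` gives 78600 nM; the step of a 1.1-fold higher number from compound 1 to compound 2 (0.06 log units; within the scatter) shows that exchanging 4-fluorophenyl for 3-methoxyphenyl leaves the number within the scatter. The steps of an 8.8-fold lower number from compound 1 to compound 3 (0.94 log units; beyond the scatter) and a 10-fold lower number from compound 2 to compound 3 (1.00 log units; beyond the scatter) are the ones that bear on the present change: both show that the aryl group on the saturated chain carbon bound to an amide-type nitrogen can move the number well beyond the scatter, and that the 3-chloro-4-fluorophenyl of compound 3 is the only one of the three that reaches the lower range.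

Compound 4 `CC(Oc1cccnc1Nc1cnn(C)c1)c1cccc(C(=O)NCc2ccccc2S(=O)(=O)C(C)C)c1` takes the step (2-(isopropylsulfonyl)phenyl in place of 3-chloro-4-fluorophenyl on a saturated chain carbon bound to an amide-type nitrogen). Among the compounds with values here, no measured step covers a sulfonyl-bearing aryl at this place, so the direct precedent is thin. What the set does show is that every aryl other than that of compound 3 sat near the higher numbers of compound 1 at 68500 nM and compound 2 at 78600 nM. The expected step for compound 4 is accordingly an increase, a 5.1-fold higher number from compound 3 to compound 4 (0.71 log units; beyond the scatter). Compound 4 is estimated at 40000 nM, with a range of 8000 nM to 150000 nM.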

Compound 4, half-maximal inhibitory concentration: 63100 nM
Estimate against measurement, compound 4: 1.6-fold (0.20 log units) below; low and high end bracket the measured number.
By their numbers in this assay, from the lowest: compound 3; then compounds 4, 1 and 2 (each within the scatter of the next).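

In this assay, the 2-(isopropylsulfonyl)phenyl does not hold the lower range reached by the 3-chloro-4-fluorophenyl, with an 8.1-fold higher number from compound 3 to compound 4 (0.91 log units; beyond the scatter) at this place. Against the other two aryl groups, the new group shows no separation, with a 1.2-fold lower number from compound 2 to compound 4 (0.10 log units; within the scatter) and a 1.1-fold lower number from compound 1 to compound 4 (0.04 log units; within the scatter), so three different aryl groups on the saturated chain carbon bound to an amide-type nitrogen now sit together and compound 3 alone stands apart from them. Nothing measured here accounts for that separation.

Open, as far as these compounds go, is whether 3-chlorophenyl, which has chloro but no fluoro, would keep the number of compound 3. Also open, from the compounds shown here alone, is what a dimethylamino group or a carboxylic acid on this aryl ring would give.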